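The compounds below may be only part of what the source reports. "The series", "measured", "known", "first", "only" and "open" are said of these compounds alone.

Measured so far:
compound 1 `COc1cc(NC(C)CCCNC(=O)NNC(=O)Nc2ccc(Br)cc2)c2ncccc2c1` gives 17000 nM in a functional assay on SW-620 cells (Homo sapiens) for inhibition, read by MTT assay, with a stated time of 72 h; a higher number here means a weaker inhibitor, a lower number a stronger inhibitor.
compound 2 `COc1cc(NC(C)CCCNC(=O)Nc2ccc(C(F)(F)F)cc2)c2ncccc2c1` gives 22000 nM in this assay.

Within the data shown here, compound 1 holds the lowest of the two numbers, but its only neighbour is close: a 1.3-fold higher number from compound 1 to compound 2 (0.11 log units; within the scatter), so no order between compound 1 and compound 2 can be read from these values.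

Compound 3 `COc1cc(NC(C)CCCNC(=O)NNC(=O)Nc2ccc(C(F)(F)F)cc2)c2ncccc2c1` is not yet measured. Against compound 1 its change is trifluoromethyl in place of bromo on an aromatic carbon. Among the measured compounds shown here, one measured step bears on it, a 1.3-fold higher number from compound 1 to compound 2 (0.11 log units; within the scatter), in which 4-(trifluoromethyl)phenyl replaces ((4-bromophenyl)carbamoyl)amino on an amide-type nitrogen; that step contains the bromo-to-trifluoromethyl exchange only together with the loss of the intervening ((4-bromophenyl)carbamoyl)amino unit, and it stays within the scatter. For the measured compounds named here, no measured pair isolates the trifluoromethyl-for-bromo exchange on its own. On this basis the expectation for compound 3 is no step beyond the scatter, a 1.2-fold higher number from compound 1 to compound 3 (0.07 log units; within the scatter). Compound 3 is therefore estimated at 20000 nM in this assay, with a range of 8000 nM to 50000 nM.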

Compound 3, half-maximal inhibitory concentration: 12000 nM
Beside the measured number, compound 3's estimate is 1.7-fold (0.22 log units) above it, within the range that was stated.
By their numbers in this assay, from the lowest: compounds 3, 1 and 2 (each within the scatter of the next).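

In this assay, the exchange of bromo for trifluoromethyl on an aromatic carbon, para to a large group, now stands alone, with a 1.4-fold lower number from compound 1 to compound 3 (0.15 log units; within the scatter) as its step. The earlier step carried the same exchange only together with the loss of the ((4-bromophenyl)carbamoyl)amino unit, whereas here everything else in the structure stays fixed, so the change of group can be read by itself. At this position, replacing bromo with trifluoromethyl, one heavy atom giving way to four and no hydrogen-bond donor or acceptor entering or leaving, produces no difference beyond the scatter, and no order can be set between the two compounds. No evidence is available that bears on this result.

Still open, from the compounds shown here alone, is whether the flat response at this position would hold for a group of another kind there, such as an amine or a carboxylic acid, in place of bromo or trifluoromethyl. Also open, going by these compounds, is whether a longer chain between the shared core and the substituted phenyl would move the number in this assay beyond the scatter.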